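A few compounds are considered here, and "the series" means these few. Any claim that something is new, unique, unknown or untested is made for them only; others in the source may bear on it.

Compound 1 `CCCCc1nc(C(C)C)c(CC(=O)OC)c(=O)n1Cc1ccc(-c2ccccc2-c2noc(=O)[nH]2)cc1` gives 9.4% in an ADME assay on microsomes from liver (Mus musculus) for metabolic stability, with a stated time of 30 min; a higher number here means that more of the compound is left, a lower number that less of the compound is left.
Compound 2 `CCCCc1nc(C)c(CC(=O)OC)c(=O)n1Cc1ccc(-c2ccccc2-c2noc(=O)[nH]2)cc1` gives 47.1% in this assay.
Compound 3 `CCCCOC(=O)Cc1c(C)nc(CCCC)n(Cc2ccc(-c3ccccc3-c3noc(=O)[nH]3)cc2)c1=O` gives 10.2% in this assay.

Compound 2 stands highest of the three numbers; its nearest neighbour is compound 3, and the gap to compound 1 is wider still. Both gaps lie beyond the scatter, so compound 2 is the compound of which most remains.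

Compound 4 `CCCCc1nc(C2CC2)c(CC(=O)OC)c(=O)n1Cc1ccc(-c2ccccc2-c2noc(=O)[nH]2)cc1` is not yet measured. It differs from compound 2 in one place: cyclopropyl in place of methyl on an aromatic carbon. Of the two measured steps, only one touches this same aromatic carbon: a number 37.7 percentage points higher from compound 1 to compound 2 (beyond the scatter), a large gain when isopropyl gave way to methyl. The other step, a number 36.9 percentage points lower from compound 2 to compound 3 (beyond the scatter), concerns the ester chain and does not bear on this change. Within the data shown here, since a group of three carbons again takes the place of methyl on that carbon, a drop is expected in this assay, though no measured compound shows how cyclopropyl in particular behaves. Compound 4 is therefore estimated at 22%, with a range from 8% to 42%. That estimate means an expected a number 25.1 percentage points lower from compound 2 to compound 4 (beyond the scatter).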

Compound 4, percent of the compound remaining: 16.4%
For compound 4 the middle estimate is 5.6 percentage points above the measured one; the range from low to high includes it.
By their numbers in this assay, from the lowest: compounds 1, 3 and 4 (each within the scatter of the next); then compound 2.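

In this assay, the change from methyl to cyclopropyl on this aromatic carbon gives a number 30.7 percentage points lower from compound 2 to compound 4 (beyond the scatter), so the loss seen earlier with isopropyl at this position is not confined to an open-chain group. Closing the three carbons into a ring brings no clear recovery, since the comparison with isopropyl gives a number 7 percentage points higher from compound 1 to compound 4 (within the scatter) and the two groups cannot be told apart here. No measured information on these compounds explains the drop from methyl to cyclopropyl.

The compounds shown do not reveal what happens with a hydrogen or an ethyl group on this carbon, so it remains unclear how small the group must be to keep the higher number. Nor do they show whether an oxygen-containing group such as methoxy, or an amine, would behave like methyl or like the three-carbon groups.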